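The compounds below may be only part of what the source reports. "The series", "measured", "known", "first", "only" and "open" are said of these compounds alone.

Compound 1 `COC(=O)c1ccc(NCc2cncn2Cc2cccc([N+](=O)[O-])c2)cc1-c1ccccc1`: > 10000 nM
Compound 2 `O=C(c1ccc(NCc2cncn2Cc2ccc(-c3ccccc3)cc2)cc1-c1ccccc1)N1CCCCC1`: > 1000 nM
Compound 3 `COC(=O)c1ccc(NCc2cncn2Cc2ccc(OC)cc2)cc1-c1ccccc1`: "not determined" (no result reported)

In a toxicity assay on NIH3T3 cells (Mus musculus) for cytotoxicity, read by resazurin assay (a higher number here means that more compound is needed for the effect, a lower number that less compound is needed), compound 2 gives only a limit, > 1000 nM. Compound 1 likewise gives only a limit, > 10000 nM. For compound 3 no result was recorded in this assay, "not determined" (no result reported). For the measured compounds named here, compound 2 therefore stands at the limit of > 1000 nM in this assay, at which 1 of the 3 values shown sits, and none of the three compounds has a single number, so no measured step between them can be drawn on. Compound 4 `c1ccc(-c2ccc(Cn3cncc3CNc3ccc(-c4ccc[nH]4)c(-c4ccccc4)c3)cc2)cc1` differs from compound 2 in one place: 1H-pyrrol-2-yl in place of (piperidin-1-yl)carbonyl on an aromatic carbon. In this assay the expected step is a step that the limit leaves unreadable from compound 2 to compound 4, which is within the scatter. Compound 4 is estimated at 5000 nM, with a range from 1000 nM to 30000 nM, and a reported limit rather than a number is considered likely.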

Compound 4, half-maximal effective concentration: > 10000 nM
Compound 4 was reported as a limit; the forecaster's own chance of this, stated with the estimate: 60%; middle value at least 2.0-fold (0.30 log units) from the limit.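

Compound 2 and compound 4 both give only limits in this assay, so no step can be read between them. The compounds shown leave open what concentration of any of them produces the effect in this assay.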